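Cytotoxicity of a Difluorophenyl Exchange on a Shared Core

The source may report more compounds than this note shows. Statements on the series, on what has been measured and on what is new or still open speak of the compounds shown alone.

The compounds here share one core, carrying a phenyl group in compound 1 `C[C@]1(CN2CCc3nc(-c4ccccc4)ccc3C2)Cn2cc([N+](=O)[O-])nc2O1`. A close relative is compound 2 `C[C@]1(CN2CCc3nc(-c4ccc(Cl)cc4)ccc3C2)Cn2cc([N+](=O)[O-])nc2O1`. The question asked of them is how harmful they are to mammalian cells, measured in an ADME assay on Vero cells (Chlorocebus sabaeus) for cytotoxicity, read by MTT assay, with a stated time of 72 h; on this read-out higher numbers stand for lower toxicity in this test and lower numbers for higher toxicity in this test.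

In this assay compound 1 gives > 32 ug/mL. That figure is a limit of the assay rather than a number. For compound 2 the entry in this assay reads "not determined" (no result reported). Of the two entries, one sits at the limit of > 32 ug/mL in this assay, at which 1 of the 2 values shown sits, and the other carries no number at all, so compound 1 stands at the edge of what this test can resolve.

Compound 3 `C[C@]1(CN2CCc3nc(-c4ccc(F)c(F)c4)ccc3C2)Cn2cc([N+](=O)[O-])nc2O1` is not yet measured. Compared with compound 1 it shows (3,4-difluorophenyl in place of phenyl on an aromatic carbon).

For the measured compounds named here, no step between measured compounds exists, so the expectation rests on compound 1 alone. The step of a number no higher from compound 1 to compound 3 (the limit leaves the size open) is expected to be none beyond the usual scatter. Compound 3 is estimated at 32 ug/mL, with a range from 16 ug/mL to 64 ug/mL, and will most likely again be reported only as a limit.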

Compound 3, half-maximal cytotoxic concentration: > 32 ug/mL
Compound 3 was reported as a limit (the forecaster's own chance of this, stated with the estimate: 70%); the middle value sits exactly at the limit.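

In this assay, compound 1 and compound 3 are each reported only as a limit and not as a number, so no step from one to the other can be read: the limit of > 32 ug/mL in this assay, at which 2 of the 3 values shown sit.

The compounds shown leave open how toxic compound 1 and compound 3 really are to these cells, and whether 3,4-difluorophenyl in place of phenyl changes that toxicity at all.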